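A few compounds are considered here, and "the series" means these few. Any claim that something is new, unique, unknown or untested is made for them only; others in the source may bear on it.

Three compounds share one core and differ only in a halogen and in where it sits. Compound 1 `Clc1ccc(OCC2=NCCO2)cc1` carries chloro; in a toxicity assay on the whole organism with Rattus norvegicus as the target, at a dose of 100 mg/kg by the oral route (a higher number here means a stronger effect of the compound at the dose given, a lower number a weaker effect), compound 1 gives 30%. Compound 3 `Clc1ccccc1OCC1=NCCO1` also carries chloro, and compound 3 gives 20%; how the cores of compound 1 and compound 3 differ is not broken down here. Compound 2 `Brc1ccccc1OCC1=NCCO1` carries bromo, and compound 2 gives 70%. The change bromo in place of chloro on an aromatic carbon produced a number 50 percentage points higher from compound 3 to compound 2 (beyond the scatter). Compound 4 `Brc1ccc(OCC2=NCCO2)cc1`, not yet measured, arises from compound 1 by bromo in place of chloro on an aromatic carbon, the same kind of change, but at a place para to a group of 7 heavy atoms instead of ortho to a group of 7 heavy atoms. Because the earlier step of a number 50 percentage points higher from compound 3 to compound 2 (beyond the scatter) was large, a rise is expected here too, and the differing place leaves room for a somewhat smaller step, so the estimate is a number 35 percentage points higher from compound 1 to compound 4 (beyond the scatter). Compound 4 is therefore expected to reach about 65%, between 40% and 90%.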

Compound 4, a percentage reported as activity, at one dose (the size of the read-out at that dose, not a potency): 60%
Compound 4: the middle estimate sits 5 percentage points above what was measured; the range from low to high includes it.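

Bromo in place of chloro on an aromatic carbon again raises the number in this assay, giving a number 30 percentage points higher from compound 1 to compound 4 (beyond the scatter). The direction of the change therefore carries over between these two cores, but the size of the step does not: the same change on two cores in this assay, a number 50 percentage points higher (beyond the scatter) from compound 3 to compound 2 and a number 30 percentage points higher (beyond the scatter) from compound 1 to compound 4, 20 percentage points apart, beyond the scatter of two such steps. These two pairs do not show that the rise would hold on any other core, and they do not separate what the core and the place of the halogen each contribute to the difference.

The compounds shown leave open how iodo or fluoro would compare with bromo and chloro. They also leave open what an amine or a longer chain in the halogen's place would give.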